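The source may hold more compounds than are shown below. What is called first, only, known or untested is meant among the compounds shown, and "the series" means these compounds.

Measured so far in a functional assay (aorta) with Oryctolagus cuniculus as the target; on this read-out higher numbers stand for weaker binding and lower numbers for tighter binding:
- compound 1 `CCCCc1nc2ccccc2n1Cc1cc(Cl)c(O)c(Cl)c1`: 63.1 nM
- compound 2 `CCCCc1nc2cccnc2n1Cc1cc(Cl)c(O)c(Cl)c1`: 63.1 nM

Compound 2, at 63.1 nM, stands level with compound 1, at 63.1 nM, and the two values are within the scatter of each other. Compound 3 `CCCc1nc2cccnc2n1Cc1cc(Cl)c(O)c(Cl)c1` departs from compound 2 at the end of the side chain: hydrogen in place of methyl on a saturated chain carbon, three bonds along the chain from an aromatic carbon. This places hydrogen in place of methyl on a saturated chain carbon, three bonds along the chain from an aromatic carbon, so that butyl becomes propyl. Among the measured compounds shown here, no measured pair shows this change, so the expectation rests on compound 2 at 63.1 nM and on the small size of the change. A small weakening is expected in this assay, possibly not beyond the scatter. The expected size is a 1.6-fold higher number from compound 2 to compound 3 (0.20 log units; within the scatter). Compound 3 is estimated at 100 nM, with an expected range of 35 nM to 290 nM.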

Compound 3, dissociation constant: 31.6 nM
Beside the measured number, compound 3's estimate is 3.2-fold (0.50 log units) above it; the measured number lies below the stated range.
By their numbers in this assay, from the lowest: compounds 3, 1 and 2 (each within the scatter of the next).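

In this assay, among the compounds shown here, going from butyl to propyl gives a 2.0-fold lower number from compound 2 to compound 3 (0.30 log units; within the scatter), the first reading of any change on this side chain. The methyl at the end of the butyl chain, on a saturated chain carbon three bonds along the chain from an aromatic carbon, can therefore give way to hydrogen without a change beyond the scatter, so the full butyl length is not needed for a value in this range. Nothing at hand explains the size or direction of this step.

Going by these compounds, whether an ethyl, a pentyl or a chain ending in an amine or a carboxylic acid would stay in the same range remains open. On these data alone, it is also open whether propyl in place of butyl on the core of compound 1 would give a step of similar size.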